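The source may report more compounds than this note shows. Statements on the series, on what has been measured and on what is new or still open speak of the compounds shown alone.

Measured compounds so far:
- Compound 1, `Cn1c(=O)c(S(=O)(=O)c2ccc(F)cc2F)cc2cnc(Nc3cccc4[nH]ccc34)nc21`, gives 1500 nM in a functional assay on K562 cells (Homo sapiens) for inhibition, read by trypan blue exclusion, with a stated time of 72 h; a higher number here means a weaker inhibitor, a lower number a stronger inhibitor.
- Compound 2, `Cn1c(=O)c(S(=O)(=O)c2ccc(F)cc2[N+](=O)[O-])cc2cnc(Nc3ccc4[nH]ccc4c3)nc21`, gives 900 nM in this assay.
- Compound 3, `Cn1c(=O)c(S(=O)(=O)c2ccc(F)cc2)cc2cnc(Nc3ccc4occc4c3)nc21`, gives 5000 nM in this assay.

All three compounds share the same core; they differ only in the aryl group attached to the sulfonyl sulfur and in the bicyclic amine on the far side of the core. In this assay compound 2 has the lowest number of the three. Its nearest neighbour is compound 1, whose number is within the usual scatter of compound 2, so no order between the two can be read from these values. Compound 3 sits beyond the scatter, and its number is clearly higher than that of compound 2.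

Compound 4, `Cn1c(=O)c(S(=O)(=O)Cc2ccc(F)cc2F)cc2cnc(Nc3ccc4[nH]ccc4c3)nc21`, has not yet been measured in this assay. It differs from compound 2 in one place: 2,4-difluorobenzyl in place of 4-fluoro-2-nitrophenyl on a sulfonyl sulfur. A ring-bound group with two hydrogen-bond acceptors is exchanged for a benzyl group with none, and a carbon is inserted between the sulfonyl sulfur and the ring.

Within the data shown here, no pair of measured compounds differs in exactly this way, so the size of the step can only be guessed. A modest step toward a higher number in this assay is expected, a 1.7-fold higher number from compound 2 to compound 4 (0.22 log units; within the scatter), though it may well stay within the scatter. Compound 4 is therefore estimated at 1500 nM, with a range from 500 nM to 5000 nM.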

Compound 4, half-maximal inhibitory concentration: 1000 nM
Beside the measured number, compound 4's estimate is 1.5-fold (0.18 log units) above it, and the stated range covers the measured number.
By their numbers in this assay, from the lowest: compounds 2, 4 and 1 (each within the scatter of the next); then compound 3.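

Swapping the group on the sulfonyl sulfur gives a 1.1-fold higher number from compound 2 to compound 4 (0.05 log units; within the scatter) in this assay, so the two compounds cannot be told apart in this read-out. Among these compounds, this is the first comparison at this position with everything else in the molecule held constant, and it shows that a compound without the 4-fluoro-2-nitrophenyl group, and with no hydrogen-bond acceptors in the group that replaces it, can give a value in the same range, even with an extra carbon placed before the ring. No other measurement shown bears on why this exchange leaves the value within the scatter, and a single pair sets no general rule for the position.

Going by these compounds, two things changed at once here, the ring's substituents and the carbon link, and what a 4-fluoro-2-nitrobenzyl group would give on the same compound stays open, so the two cannot be weighed separately. Also open, on these data alone, is how a longer chain such as 2-phenylethyl, or a group carrying an amine or a carboxylic acid, would read at this sulfonyl sulfur.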